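N-Methylation of the Pyrazole and Expected Half-Life

The source may hold more compounds than are shown below. What is called first, only, known or untested is meant among the compounds shown, and "the series" means these compounds.

Compound 1 (`CC(=O)Nc1cc(-c2c(Nc3cc[nH]n3)nc3ccccn23)nc(C)n1`) was examined in an in vivo ADME assay on the whole organism for metabolic stability, with Rattus norvegicus as the target, at a dose of 0.5 mg/kg by the intravenous route (on this read-out lower numbers stand for a shorter-lived compound and higher numbers for a longer-lived compound), where compound 1 gives 0.52 h. Among the compounds with values here, only one other compound shares this read-out: compound 2 (`Cc1nc(N)nc(-c2c(Nc3ccn(C)n3)nc3ccc(-c4cncnc4)cn23)n1`), which in this assay gives 0.26 h, a number that sits within the scatter of the value for compound 1, so the two cannot be ranked against each other. Compound 3 (`CC(=O)Nc1cc(-c2c(Nc3ccn(C)n3)nc3ccccn23)nc(C)n1`) has not yet been measured. It differs from compound 1 in one respect, methyl in place of hydrogen on an aromatic nitrogen. Within the data shown here, no measured pair shows this change on its own, so there is no step from which its size can be read. The expectation for compound 3 is therefore a small step, a 1.2-fold lower number from compound 1 to compound 3 (0.06 log units; within the scatter), no larger than the scatter and without a clear direction. On that basis compound 3 is estimated at 0.45 h, within a range from 0.2 h to 1 h.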

Compound 3, half-life: 0.66 h
Beside the measured number, compound 3's estimate is 1.5-fold (0.17 log units) below it; the measured number falls inside the stated range.
By their numbers in this assay, from the lowest: compounds 2, 1 and 3 (each within the scatter of the next, the first and the last beyond it).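

Read on its own in this assay, methyl in place of hydrogen on the aromatic nitrogen gives a 1.3-fold higher number from compound 1 to compound 3 (0.10 log units; within the scatter), so compound 1 and compound 3 cannot be ranked on this read-out. At this position, therefore, 1H-pyrazol-3-yl and 1-methyl-1H-pyrazol-3-yl are not told apart by half-life, and the hydrogen on that nitrogen is shown not to be required for a half-life in the range of compound 1. No measurement at hand explains this outcome.

As far as these compounds go, it remains open whether a larger group on the same nitrogen, such as ethyl, isopropyl or a longer chain, would also leave the half-life within the scatter. Whether the same methyl change behaves alike when the rest of the molecule differs also stays unresolved.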